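A few compounds are considered here, and "the series" means these few. Any claim that something is new, unique, unknown or untested is made for them only; others in the source may bear on it.

Measured in an ADME assay on cells (Fibroblast, Homo sapiens) for antiproliferative activity, with a stated time of 48 h; on this read-out lower numbers stand for stronger inhibition and higher numbers for weaker inhibition:
- compound 1 `CCN(CC)c1ccc(-c2cccc(C(F)(F)F)c2)nn1`: > 25000 nM
- compound 2 `CCN(CC)c1ccc(-c2cccc(C#N)c2)nn1`: > 25000 nM
- compound 3 `CCOC(=O)c1cccc(-c2ccc(N(CC)CC)nn2)c1`: > 25000 nM

Each of these readings is a limit of the assay and not a number. Compound 1 stands at a limit, > 25000 nM. It has no better or worse place among the three, since all of them share (the limit of > 25000 nM in this assay, at which 3 of the 3 values shown sit).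

Compound 4 `FC(F)(F)c1cccc(-c2ccc(Oc3ccccc3)nn2)c1` differs from compound 1 in one place, with phenoxy in place of diethylamino on an aromatic carbon.

Going by the values given here, no measured step touches that place. The other steps exchange only the trifluoromethyl, cyano and ethoxycarbonyl groups, and none has a readable size: a step that the two limits leave unreadable from compound 1 to compound 2, a step that the two limits leave unreadable from compound 1 to compound 3 and a step that the two limits leave unreadable from compound 2 to compound 3. They therefore give no guide to the size or direction of this change. Among the compounds with values here, with no sign of measurable inhibition in this assay so far, the best expectation is that compound 4 stays close to the same limit, with no clear change. The estimated step is a step that the limit leaves unreadable from compound 1 to compound 4. Compound 4 is expected to give 30000 nM, within an estimated range of 12000 nM to 60000 nM.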

Compound 4, half-maximal inhibitory concentration: > 25000 nM
Compound 4: a limit, no number; the forecaster's own chance of this, stated with the estimate: 75%; the middle value lies beyond the limit too.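

No size or direction can be read for the change from diethylamino in compound 1 to phenoxy in compound 4, since both readings are limits of the assay and not numbers: the limit of > 25000 nM in this assay, at which 4 of the 4 values shown sit.

The compounds shown leave open whether any change to the shared core can bring a measurable value in this assay, and how these four compounds rank against one another.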